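The compounds below may be only part of what the source reports. "The series", "measured", "known", "first", "only" and "open" are said of these compounds alone.

Measured compounds: compound 1 `CSc1ccc(/C=C2\CCCN=C2c2cccnc2)cc1` with 900 nM in an assay on membranes from brain for displacement of a labelled ligand from Neuronal acetylcholine receptor; alpha4/beta2 (Rattus norvegicus), with a stated time of 3 h; a lower number here means a stronger inhibitor, a higher number a weaker inhibitor; compound 2 `COc1ccc(/C=C2\CCCN=C2c2cccnc2)c(OC)c1` with 250 nM in this assay.

Compound 1 gives the higher of the two numbers seen in this assay; the number for compound 2 is lower, and the gap between them lies beyond the usual scatter of repeated measurements. Within the data shown here, no step between one-place neighbours has been worked out for this pair, so only the two values themselves are on hand.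

Compound 3 `CCCCOc1ccc(/C=C2\CCCN=C2c2cccnc2)cc1` has not been measured in this assay. It differs from compound 1 in one place: butoxy in place of methylsulfanyl on an aromatic carbon. The group that enters sits on an aromatic carbon, para to a large group, as the methylsulfanyl did.

Nothing measured in the series fixes the size of such a change. The expected step of a 1.1-fold lower number from compound 1 to compound 3 (0.05 log units; within the scatter) is therefore none beyond the scatter, with the direction left open. On that basis the number for compound 3 in this assay is estimated at 800 nM, within a range from 250 nM to 2500 nM.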

Compound 3, inhibition constant: 1960 nM
Compound 3: the middle estimate sits 2.5-fold (0.39 log units) below what was measured; low and high end bracket the measured number.
By their numbers in this assay, from the lowest: compound 2; then compound 1; then compound 3.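

In this assay, the aromatic carbon para to a large group now has a measured one-place step: butoxy in place of methylsulfanyl gives a 2.2-fold higher number from compound 1 to compound 3 (0.34 log units; beyond the scatter), so the number at this position does depend on the group it carries. The change is a double one, since the atom bound to the ring goes from sulfur to oxygen while the chain grows from the 2 heavy atoms of methylsulfanyl to the 5 of butoxy, and this single step cannot separate those two parts. No measurement is at hand that accounts for the higher number.

Still open, on these data alone, is which part of the exchange carries the step: a methoxy group at this same carbon would set oxygen against sulfur with the chain length held, while a butylsulfanyl chain would set the longer chain against methylsulfanyl with sulfur kept. An amine or a carboxylic acid at this carbon is also untested in the compounds shown, and compound 2 differs from compound 1 and compound 3 in more than one place, so it gives no one-place reading of this position.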